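A Bromo for Methyl Swap on Compound 1

A few compounds are considered here, and "the series" means these few. Any claim that something is new, unique, unknown or untested is made for them only; others in the source may bear on it.

Measured in an ADME assay on J774 cells (Mus musculus) for cytotoxicity; a lower number here means that less compound is needed, a higher number that more compound is needed for the effect
compound 1 `COC(=O)c1c[nH]c2cc(OCCOc3ccccc3)c(C)cc2c1=O` gives > 20000 nM
compound 2 `COC(=O)c1c[nH]c2cc(Oc3ccccc3)ccc2c1=O` gives 9120 nM
compound 3 `COC(=O)c1c[nH]c2ccc(OC)cc2c1=O` gives 6180 nM

Compound 1 has no numerical reading in this assay and is known only by a limit (> 20000 nM). Its standing among the three compounds is the limit of > 20000 nM in this assay, at which 1 of the 3 values shown sits, and no more can be said of its place. Compound 2 (9120 nM) returned a number, and so did compound 3 (6180 nM).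

The next compound to be tested is compound 4 `COC(=O)c1c[nH]c2cc(OCCOc3ccccc3)c(Br)cc2c1=O` which differs from compound 1 at one place. It has bromo in place of methyl on an aromatic carbon, ortho to a large group bromo in place of methyl on an aromatic carbon and the rest of the structure is unchanged. Going by the values given here, no measured pair shows what such a swap does, so the expectation rests on the limit of compound 1 (> 20000 nM) alone. The expected step, an at least 1.1-fold lower number from compound 1 to compound 4 (0.04 log units; that floor lies within the scatter) is not expected to go beyond the usual scatter, and no firm direction is expected. Compound 4 may well report only a limit too. The estimate for compound 4 is 18000 nM with an expected range from 9000 nM to 40000 nM in this measurement.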

Compound 4, half-maximal effective concentration: > 20000 nM
Compound 4: only a limit was reported; the forecaster's own chance of this, stated with the estimate: 55%; middle value at least 1.1-fold (0.04 log units) away from the limit.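

Going by these compounds alone, compound 1 and compound 4 each returned only a limit in this assay: the limit of > 20000 nM in this assay, at which 2 of the 4 values shown sit. No step for bromo in place of methyl on an aromatic carbon can therefore be read between these two compounds. The compounds shown leave open whether this swap changes the reading at all, and in which direction.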